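The compounds below may be only part of what the source reports. "The series", "measured", "known", "first", "only" and "open" are said of these compounds alone.

Compound 1 `COc1cc(-n2ncnc2-c2ccc(F)cc2)cc(OC)c1OC`: in a functional assay on HeLa cells (Homo sapiens) for antiproliferative activity, read by MTT assay, with a stated time of 72 h (on this read-out higher numbers stand for weaker inhibition and lower numbers for stronger inhibition), compound 1 gives > 10000 nM, which is a limit of the assay and not a number.

Compound 2 `COc1cc(-c2ncnn2-c2ccc([N+](=O)[O-])cc2)cc(OC)c1OC`: in this assay compound 2 gives > 10000 nM, again a limit and not a number.

Compound 1 thus stands at the edge of what the assay can report, as do all values shown here (the limit of > 10000 nM in this assay, at which 2 of the 2 values shown sit). Compound 3 `CCOc1ccc(-c2ncnn2-c2cc(OC)c(OC)c(OC)c2)cc1` differs from compound 1 by ethoxy in place of fluoro on an aromatic carbon. For the measured compounds named here, no two measured compounds differ in a single place, so no measured step is available for guidance. In this assay the step expected is one of no change beyond the usual scatter a step that the limit leaves unreadable from compound 1 to compound 3. Compound 3 is therefore estimated at 15000 nM, with a range from 4000 nM to 60000 nM.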

Compound 3, half-maximal inhibitory concentration: 15 nM
For compound 3 the middle estimate is 1000-fold (3.00 log units) above the measured one; measured number outside the range, below it.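

This position is not indifferent to what sits on it: in this assay, ethoxy in place of fluoro on this aromatic carbon gives an at least 660-fold lower number from compound 1 to compound 3 (2.82 log units; beyond the scatter), a large step. Compound 1 gives > 10000 nM, which is a limit and not a number. The true size of the step therefore stays unknown, since one end of it rests on that limit: the limit of > 10000 nM in this assay, at which 2 of the 3 values shown sit.

As far as these compounds go, how a methoxy group, a longer propoxy chain or an amine at this place would compare with ethoxy stays open. The compounds shown also give no reason for the step.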